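This account rests on a few compounds, and the source may have more. Where it says the series, first, only, none or still open, it means among the compounds named here.

Working notes on the series. Compound 1 `O=C(O)c1cccc([C@H]2C[C@@H](c3ccc(OCc4c(-c5c(Cl)cccc5Cl)noc4C4CC4)cc3Cl)C2)c1` and compound 2 `CS(=O)(=O)NC(=O)c1ccc(C2CC2c2ccc(OCc3c(-c4c(Cl)cccc4Cl)noc3C3CC3)cc2Cl)cc1` sit level at the top of the three numbers in hand: in an assay on HEK293 cells for agonist activity at Bile acid receptor (Homo sapiens) (a higher number here means a larger maximal response, a lower number a smaller maximal response), compound 1 gives 88%, and compound 2 gives 88%, no change at the digits printed and within the scatter, so no order between the two is claimed. Compound 3 `O=C(O)c1cncc(N2CC(O)(c3ccc(OCc4c(-c5c(Cl)cccc5Cl)noc4C4CC4)cc3Cl)C2)c1` is the compound furthest from compound 1: in this assay compound 3 gives 71%, a lower number that lies beyond the scatter. No step between measured compounds that differ in a single place exists in this set, so compound 3 only shows that a lower maximal response occurs in the series; no cause is drawn from it.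

Compound 4 `CO[C@]1(c2ccc(OCc3c(-c4c(Cl)cccc4Cl)noc3C3CC3)cc2Cl)C[C@H](c2cccc(C(=O)O)c2)C1` is the untested member, derived from compound 1 by methoxy in place of hydrogen on a saturated ring carbon. Going by the values given here, no measured pair in this set carries this change, so the step is read without a direct precedent. The expected step in this assay is small and, if anything, downward; a result with no change beyond the scatter is also well possible. Compound 4 is therefore expected at 80%, with the range 65% to 95%, which corresponds to an expected step of a number 8 percentage points lower from compound 1 to compound 4 (within the scatter).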

Compound 4, largest response reached (reported as efficacy), in percent of the reference or control that the assay uses: 75%
Compound 4: the middle estimate sits 5 percentage points above what was measured, within the range that was stated.
By their numbers in this assay, from the lowest: compounds 3 and 4 (each within the scatter of the next); then compounds 1 and 2 (each within the scatter of the next).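

Going by these compounds alone, compound 4 supplies the only single-place step in this set: in this assay, methoxy in place of hydrogen on a saturated ring carbon of the four-membered ring gives a number 13 percentage points lower from compound 1 to compound 4 (beyond the scatter) and so separates this change from the core of compound 1. The position is therefore not silent to substitution, since this one replacement of a hydrogen atom, adding only 2 heavy atoms two ring bonds from the ring atom that bears the 3-carboxyphenyl group, is enough to move the maximal response beyond the usual scatter. Yet the step is modest and a substantial maximal response remains with methoxy in place, and nothing measured on these compounds bears on what lies behind the step.

The compounds shown leave open whether the lower maximal response belongs to methoxy in particular or to any substituent on this carbon, a question that fluorine, ethoxy or an amine at the same place would address. Also open, on these data alone, is whether the step is specific to this ring carbon and its spatial arrangement, or would recur with methoxy on the opposite face of the four-membered ring.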